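Swapping the Ring Substituents on a Piperidine Antagonist

The source may hold more compounds than are shown below. What is called first, only, known or untested is meant among the compounds shown, and "the series" means these compounds.

Of the compounds shown here, three have been measured in a functional assay for antagonist activity at transient receptor potential cation channel subfamily V member 1 (Homo sapiens), read by FLIPR and calcium flux; a lower number here means a stronger inhibitor, a higher number a weaker inhibitor. Compound 1, `O=C1CSc2ccc(NC(=O)C3CCN(c4cc(F)c(F)c(F)c4)CC3)cc2N1`, gives 1960 nM in this assay. Compound 2, `O=C1COc2ccc(NC(=O)C3CCN(c4ccccc4Cl)CC3)cc2N1`, gives 220 nM in this assay. Compound 3, `O=C(Nc1cnc2ccccc2c1)C1CCN(c2cccc(C(F)(F)F)c2)CC1`, gives 600 nM in this assay. Compound 2 therefore stands lowest of the three numbers, which here means the strongest inhibitor: the gap to compound 3 is beyond the scatter, and the gap to compound 1 is larger still. Compound 4, `Cc1cccc(N2CCC(C(=O)Nc3ccc4c(c3)NC(=O)CO4)CC2)c1C`, has not yet been measured in this assay. It differs from compound 2 in a single place: 2,3-dimethylphenyl in place of 2-chlorophenyl on an amine nitrogen in a ring. Going by the values given here, no two of the measured compounds differ in only one place, so no measured step can guide the size of this change directly. The two aromatic groups carry no hydrogen-bond donors or acceptors and no charge, and they are alike in size, so only a small move is expected, likely none beyond the scatter, with a slight lean toward a weaker inhibitor. Compound 4 is estimated to give 320 nM in this assay, between 110 nM and 950 nM, an expected step of a 1.5-fold higher number from compound 2 to compound 4 (0.16 log units; within the scatter).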

Compound 4, half-maximal inhibitory concentration: 60 nM
Compound 4: the middle estimate sits 5.3-fold (0.73 log units) above what was measured, outside the stated range (below it).
By their numbers in this assay, from the lowest: compound 4; then compound 2; then compound 3; then compound 1.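

Swapping 2-chlorophenyl for 2,3-dimethylphenyl on an amine nitrogen in a ring gives, in this assay, a 3.7-fold lower number from compound 2 to compound 4 (0.56 log units; beyond the scatter), a move beyond the usual scatter toward a stronger inhibitor. This position therefore responds to an exchange between two groups that look much alike when counted: each is one six-membered aromatic ring of carbon only, with no hydrogen-bond donors or acceptors and no net charge. No two of the earlier compounds differed in only one place, so this is the first measured size of a change here, and no data shown say why it runs in this direction.

This single step cannot separate the loss of the chlorine from the arrival of the two methyl groups, and an aromatic ring carrying a single methyl group, or both a methyl group and a chlorine, would be needed to pull the two apart. Also open, on these data alone, are whether a methoxy group or a pyridine ring at this place would keep the stronger inhibition, and whether the same swap would act alike on the different cores of compound 1 and compound 3.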